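Replacing a dimethylphenyl with a furan on a shared core

The compounds below may be only part of what the source reports. "The series", "measured", "known", "first", "only" and "open" are said of these compounds alone.

Compound 1 `COc1ccc(-c2cnn3c(NCc4ccccn4)cc(C)nc23)cc1` in a physicochemical assay for solubility, read by HPLC, using the shake flask method, measured as kinetic solubility, with a stated time of 2 h, at pH 7.4 (a lower number here means a less soluble compound, a higher number a more soluble compound), gives < 5000 nM, which is a limit of the assay and not a number.
Compound 2 `Cc1cc(NCc2ccccn2)n2ncc(-c3cccc(F)c3)c2n1` in this assay gives 5000 nM.
Compound 3 `Cc1cc(NCc2ccccn2)n2ncc(-c3c(C)cccc3C)c2n1` in this assay gives < 5000 nM, which is a limit of the assay and not a number.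

Compound 3 therefore stands at the limit of < 5000 nM in this assay, at which 2 of the 3 values shown sit, so its true solubility is not fixed by the numbers. Compound 4 `Cc1cc(NCc2ccccn2)n2ncc(-c3ccco3)c2n1` differs from it in one place: furan-2-yl in place of 2,6-dimethylphenyl on an aromatic carbon. The measured steps give little guidance here. The step that the two limits leave unreadable from compound 1 to compound 3 cannot be sized, and the step of a number no higher from compound 2 to compound 3 (the limit leaves the size open) is only bounded on one side; neither involves a furan-2-yl. With compound 3 itself at a limit, no size of step can be read for the change to compound 4, and the expected step of a number no lower from compound 3 to compound 4 (the limit leaves the size open) is accordingly uncertain in both size and direction. On balance compound 4 is estimated to reach 5000 nM in this assay, with a plausible range from 1500 nM to 20000 nM, and a fair chance that only a limit is reported again.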

Compound 4, solubility: 48800 nM
Beside the measured number, compound 4's estimate is 9.8-fold (0.99 log units) below it; the measured number lies above the stated range.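

Before compound 4, this position, on an aromatic carbon of a five-membered aromatic ring with 2 nitrogen, offered almost no step of readable size in this assay: the limit of < 5000 nM in this assay, at which 2 of the 4 values shown sit.

Furan-2-yl now gives the first step with a definite size, a 9.8-fold higher number from compound 2 to compound 4 (0.99 log units; beyond the scatter), so the group at this position can move the read-out well beyond the scatter.

The other two steps are open-ended, since each starts from a limit, but they point the same way: an at least 9.7-fold higher number from compound 3 to compound 4 (0.98 log units; beyond the scatter), and an at least 9.7-fold higher number from compound 1 to compound 4 (0.98 log units; beyond the scatter).

The compounds shown cannot separate the change in ring size from the ring oxygen, since furan-2-yl brings both at once. On these data alone, whether a thiophene, with sulfur in place of that oxygen, or an unsubstituted phenyl would sit nearer compound 4 or compound 2 remains open.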